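A few compounds are considered here, and "the series" means these few. Any claim that something is new, unique, unknown or untested is made for them only; others in the source may bear on it.

Two compounds of the series, both carrying the same amide-linked portion, have been measured in a functional assay on K562 cells (Homo sapiens) for inhibition, read by MTT assay and WST assay, with a stated time of 72 h, tested at 10 uM; on this read-out lower numbers stand for less inhibition of growth and higher numbers for more inhibition of growth at the one concentration tested. Compound 1 `CCN1CCN(c2cc(Nc3ccc4sc(C(=O)Nc5c(C)cccc5Cl)cc4c3)nc(C)n2)CC1` gives 33.9% in this assay. Compound 2 `COc1cc2c(Nc3ccc4sc(C(=O)Nc5c(C)cccc5Cl)cc4c3)ncnc2cc1OCCCN1CCN(C)CC1`, built on a different core, gives 51.2% in this assay. Compound 1 thus stands lowest of the two numbers; the nearest, compound 2, lies higher by a margin beyond the scatter. Among the compounds with values here, the two differ in more than one place, so no single step between them can be drawn from the pair, and only the two values themselves are known.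

The next compound, compound 3 `Cc1nc(Nc2ccc3sc(C(=O)Nc4c(C)cccc4Cl)cc3c2)cc(N2CCN(C)CC2)n1`, keeps the core of compound 1 and differs from it in one place: hydrogen in place of methyl on a saturated chain carbon bound to an amine nitrogen in a ring. Cut one bond further out this reads ethyl to methyl, 4-ethylpiperazin-1-yl to 4-methylpiperazin-1-yl. Within the data shown here, no measured pair shows such a step, so its size is not known from these data. The change removes one carbon and touches no ring, donor or acceptor; the step of a number 1.1 percentage points higher from compound 1 to compound 3 (within the scatter) is expected to lie within the scatter, in no clear direction. Compound 3 is therefore estimated to give 35% in this assay, within a range from 20% to 50%.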

Compound 3, percent growth inhibition at one concentration: 32.4%
Compound 3: middle estimate off by 2.6 percentage points, on the high side; low and high end bracket the measured number.
By their numbers in this assay, from the lowest: compounds 3 and 1 (each within the scatter of the next); then compound 2.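

In this assay, within the data shown here, the change from 4-ethylpiperazin-1-yl to 4-methylpiperazin-1-yl gives a number 1.5 percentage points lower from compound 1 to compound 3 (within the scatter) and is the first step that can be read at a single place. At this place, on a saturated chain carbon bound to an amine nitrogen in a ring, removing one carbon therefore leaves growth inhibition at the one concentration tested within the scatter, and ethyl and methyl cannot be told apart on the core of compound 1. Nothing at hand explains this result.

Among these compounds, open is whether a longer chain such as propyl, a hydroxyethyl chain, or a hydrogen on the same ring amine nitrogen would also stay within the scatter on this core, since the single step covers only ethyl and methyl. Among the compounds shown here, compound 2 differs from compound 1 and from compound 3 in more than one place, so no step to it can be read, and what separates its number from theirs remains unassigned.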